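This account rests on a few compounds, and the source may have more. Where it says the series, first, only, none or still open, it means among the compounds named here.

Measured so far:
- compound 1, `O=C(Nc1cccc(-c2nc3ccccc3s2)c1)c1cc([N+](=O)[O-])ccc1Cl`: 12 10^-6 cm/s in an ADME assay for permeability, using PAMPA, at pH 7.4; on this read-out higher numbers stand for higher permeability and lower numbers for lower permeability
- compound 2, `O=C(Nc1cccc(-c2nc3ccccc3[nH]2)c1)c1cc([N+](=O)[O-])ccc1Cl`: 352 10^-6 cm/s

Compound 2 stands highest of the two numbers in this assay; compound 1 is the nearest, with a 29-fold higher number from compound 1 to compound 2 (1.47 log units; beyond the scatter) separating them. Compound 3, `O=C(Nc1cccc(-c2ccccc2)c1)c1cc([N+](=O)[O-])ccc1Cl`, carries phenyl in place of 1H-benzimidazol-2-yl on an aromatic carbon. Among the compounds with values here, no measured step removes the whole group in this way; the one step known, from compound 1 to compound 2, only exchanges one hetero atom within the 1H-benzimidazol-2-yl and still moves the number far. The step from compound 2 to compound 3 is therefore expected to be a decrease, a 3.5-fold lower number from compound 2 to compound 3 (0.55 log units; beyond the scatter), with wide uncertainty. Compound 3 is estimated at 100 10^-6 cm/s, within 20 10^-6 cm/s to 400 10^-6 cm/s.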

Compound 3, apparent permeability in the ADME assay: "below limit of detection" (no number reported)
Compound 3: no number reported; there is nothing to compare the estimate with.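

Within the data shown here, compound 3 gives no number in the ADME assay, so no step from compound 2 to compound 3 can be read there. In a physicochemical assay for solubility, read by spectrophotometry, in phosphate buffer, measured as kinetic solubility, with a stated time of 18 h, at pH 7.4 (on this read-out higher numbers stand for higher solubility and lower numbers for lower solubility), compound 2 gives 1400 nM and compound 3 gives 410 nM. The compounds shown leave open where compound 3 stands relative to compound 1 and compound 2 in the ADME assay.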